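The compounds below may be only part of what the source reports. "The series", "measured", "known", "first", "only" and "open" are said of these compounds alone.

In a functional assay on HCT-116 cells (Homo sapiens), read by sulforhodamine B assay, with a stated time of 5 days (on this read-out higher numbers stand for weaker inhibition of growth and lower numbers for stronger inhibition of growth), compound 1 `OC[C@H]1O[C@@H](n2cc(Cl)c3c(-c4ccccc4)ncnc32)[C@H](O)[C@@H]1O`, with phenyl on the shared core, gives 1400 nM, and compound 2 `OC[C@H]1O[C@@H](n2cc(Cl)c3c(-c4cccs4)ncnc32)[C@H](O)[C@@H]1O`, with thiophen-2-yl in its place, gives 270 nM. Compound 2 therefore holds the lower of the two numbers. Compound 3 `OC[C@H]1O[C@@H](n2cc(Cl)c3c(-c4ccsc4)ncnc32)[C@H](O)[C@@H]1O` has the same atoms joined differently: thiophen-3-yl in place of thiophen-2-yl on an aromatic carbon. Within the data shown here, the only measured step that bears on this change is a 5.2-fold lower number from compound 1 to compound 2 (0.71 log units; beyond the scatter). Among the measured compounds shown here, that step replaced one ring with another, whereas here the thiophene stays and only its point of attachment moves, so no measured step shows directly what such a move does. A smaller change in this assay is expected, probably not beyond the scatter, with a slight lean towards a higher number. The expected step is a 1.3-fold higher number from compound 2 to compound 3 (0.11 log units; within the scatter). Compound 3 is estimated at 350 nM, within a range of 120 nM to 1000 nM.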

Compound 3, concentration for 50% growth inhibition: 100 nM
Compound 3: middle estimate off by 3.5-fold (0.54 log units), on the high side; measured number below the stated range.
By their numbers in this assay, from the lowest: compound 3; then compound 2; then compound 1.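

In this assay, moving the point of attachment alone changes the result, with a 2.7-fold lower number from compound 2 to compound 3 (0.43 log units; beyond the scatter) even though thiophen-3-yl and thiophen-2-yl have the same atoms and sit on the same aromatic carbon. The step away from phenyl is correspondingly larger, at a 14-fold lower number from compound 1 to compound 3 (1.15 log units; beyond the scatter) for this isomer, so the two thiophenes are not interchangeable at this position, and compound 3 holds the lowest number of the three. Nothing given here accounts for the difference between the two points of attachment.

Going by these compounds, it remains open whether furan-3-yl or a thiazole would follow thiophen-3-yl, and whether a methyl group on the thiophene ring would keep the number this low. On these data alone, all three compounds also share the same chlorine on the core, so it is unknown whether this order would hold with a bromine or a nitrile there.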